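Swapping the ring-nitrogen phenyl for a dimethoxyphenyl

This account rests on a few compounds, and the source may have more. Where it says the series, first, only, none or still open, it means among the compounds named here.

Measured so far:
- compound 1, `O=C(NCCCCc1ccccc1)c1cccc(C2SCC(=O)N2c2ccccc2)c1`, 60%
- compound 2, `O=C(NCCCCc1ccccc1)c1cccc(C2OCC(=O)N2c2cccc(F)c2)c1`, 0%
- compound 3, `COc1ccccc1N1C(=O)CSC1c1cc(F)cc(C(=O)O)c1`, 0%

In a functional assay on 143B cells (Homo sapiens) for inhibition, read by CCK-8 assay, with a stated time of 72 h, tested at 1 uM (on this read-out lower numbers stand for less inhibition and higher numbers for more inhibition at the one concentration tested (going by the name of the read-out)), compound 1 gives 60%, the highest of the three numbers, and both compound 2 and compound 3 lie far below it, beyond the usual scatter. Compound 4, `COc1ccc(N2C(=O)CSC2c2cccc(C(=O)NCCCCc3ccccc3)c2)c(OC)c1`, is not yet measured. It differs from compound 1 in one place: 2,4-dimethoxyphenyl in place of phenyl on an amide-type nitrogen in a ring. No pair of measured compounds differing in a single place is available, so the size of this step cannot be read from the numbers shown. A modest change is expected, most likely a small loss of inhibition or none beyond the scatter, and compound 4 is estimated at 45% with a range of 15% to 75%. This estimate implies a step of a number 15 percentage points lower from compound 1 to compound 4 (beyond the scatter) in this assay.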

Compound 4, a percentage reported as inhibition, at one concentration (the size of the read-out at that concentration, not a potency): 53%
Compound 4: the middle estimate sits 8 percentage points below what was measured, within the range that was stated.
By their numbers in this assay, from the lowest: compounds 2 and 3 (each within the scatter of the next); then compounds 4 and 1 (each within the scatter of the next).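

In this assay, within the data shown here, the swap to 2,4-dimethoxyphenyl gives a number 7 percentage points lower from compound 1 to compound 4 (within the scatter) and so no step that can be told apart from the scatter. This position, on an amide-type nitrogen in a ring, therefore holds inhibition with a larger group carrying two hydrogen-bond acceptors in place of phenyl. Nothing shown explains this result.

Compound 2 and compound 3 differ from compound 1 in more than one place, so those steps cannot be read. From the compounds shown here alone, whether the same position keeps inhibition with an amine or a carboxylic acid on the phenyl ring stays open.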